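Azole swap on the acid-bearing carbon: triazole to tetrazole

The source may hold more compounds than are shown below. What is called first, only, known or untested is meant among the compounds shown, and "the series" means these compounds.

Compound 3 `Cc1nc(-c2ccc(C(F)(F)F)cc2)sc1COc1ccc([C@H](CC(=O)O)c2ncnn2C)cc1` gives 65 nM in an assay on CHO cells for agonist activity at Free fatty acid receptor 1 (Homo sapiens), read by calcium flux (a higher number here means that more compound is needed for the effect, a lower number that less compound is needed), which places it second highest of the three numbers measured. Its nearest neighbour is compound 2 `Cc1nc(-c2ccc(C(F)(F)F)cc2)sc1COc1ccc([C@H](CC(=O)O)c2nccn2C)cc1`, which gives 73 nM; compound 1 `Cc1cc(Cl)ccc1-c1cccc(COc2ccc([C@H](CC(=O)O)c3ncnn3C)cc2)c1` gives 33 nM, and its gap to compound 3 is also within the scatter.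

The step to compound 4 `Cc1nc(-c2ccc(C(F)(F)F)cc2)sc1COc1ccc([C@H](CC(=O)O)c2nnnn2C)cc1` is 1-methyl-1H-tetrazol-5-yl in place of 1-methyl-1H-1,2,4-triazol-5-yl on a saturated chain carbon bound to an aromatic carbon and a saturated chain carbon. Among the measured compounds shown here, only one measured step touches the same position: a 1.1-fold lower number from compound 2 to compound 3 (0.05 log units; within the scatter), an exchange of one five-membered aromatic ring for another that left the number where it was. The change from compound 3 to compound 4 is again an exchange of one such ring for a close relative on the same carbon, so the same picture is expected in this assay: no step beyond the scatter. Compound 4 is therefore expected to give 70 nM, with a range from 30 nM to 160 nM. This corresponds to an expected step of a 1.1-fold higher number from compound 3 to compound 4 (0.03 log units; within the scatter).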

Compound 4, half-maximal effective concentration: 41 nM
Compound 4: the middle estimate sits 1.7-fold (0.23 log units) above what was measured, and the stated range covers the measured number.
By their numbers in this assay, from the lowest: compounds 1, 4, 3 and 2 (each within the scatter of the next, the first and the last beyond it).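

In this assay, the exchange of 1-methyl-1H-1,2,4-triazol-5-yl for 1-methyl-1H-tetrazol-5-yl gives a 1.6-fold lower number from compound 3 to compound 4 (0.20 log units; within the scatter), and the exchange of 1-methyl-1H-imidazol-2-yl for the same tetrazole gives a 1.8-fold lower number from compound 2 to compound 4 (0.25 log units; within the scatter). A third five-membered aromatic ring, now with 4 hetero atoms, therefore joins the other two on this saturated chain carbon without any step beyond the scatter, so all three rings are interchangeable here in this assay on the shared core of compounds 2, 3 and 4. Nothing available explains this outcome at the molecular level.

Going by these compounds, whether the tetrazole would behave the same way on the core of compound 1 remains open. So does whether a larger group on this carbon, such as a phenyl ring or a 1-ethyl in place of the 1-methyl on the azole, would also stay within the scatter.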